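The compounds below may be only part of what the source reports. "The series", "measured", "known", "first", "only" and "open" are said of these compounds alone.

The measured compounds, in a functional assay on HCT-116 cells (Homo sapiens) for antiproliferative activity, read by MTT assay, with a stated time of 48 h; on this read-out lower numbers stand for stronger inhibition and higher numbers for weaker inhibition:

Compound 1 `C#CCOc1ccc(/C=C/C(C)=O)cc1OC` gives 49700 nM.
Compound 2 `COc1cc(/C=C/C(C)=O)ccc1OCc1cn(-c2ccccc2CO)nn1` gives only a limit of this assay, > 100000 nM.
Compound 3 `COc1cc(/C=C/C(C)=O)ccc1OCc1cn(-c2ccc(/N=N/c3ccccc3)cc2)nn1` gives only a limit of this assay, > 100000 nM.

Compound 3 therefore stands at the upper edge of what this assay reports: its value is a limit and not a number, and it shares that position with one of the two other values shown, a point summed up as the limit of > 100000 nM in this assay, at which 2 of the 3 values shown sit. Only compound 1 carries a number, and it too sits far toward the weak end.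

Compound 4 `COc1cc(/C=C/C(C)=O)ccc1OCc1cn(-c2ccc(NC(=O)c3ccccc3)cc2)nn1` differs from compound 3 at one place: a group of 9 heavy atoms (7 carbon, 1 nitrogen, 1 oxygen; one six-membered aromatic ring of carbon only) in place of a group of 8 heavy atoms (6 carbon, 2 nitrogen; one six-membered aromatic ring of carbon only), on an aromatic carbon. The benzamido group enters on an aromatic carbon, para to a large group. Within the data shown here, no pair of measured compounds carries a comparable step, and with compound 3 at a limit the direction of any change cannot be read from the numbers. The step from compound 3 to compound 4 is expected to be small, a step that the limit leaves unreadable from compound 3 to compound 4, nothing beyond the scatter. Compound 4 is expected to give 120000 nM, with a range from 50000 nM to 300000 nM, and most likely this assay again reports only a limit for it.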

Compound 4, half-maximal inhibitory concentration: > 100000 nM
Compound 4: only a limit was reported (the forecaster's own chance of this, stated with the estimate: 65%); the middle value lies beyond the limit too.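

Among these compounds, compound 3 and compound 4 each give only a limit in this assay, so no step between them can be read. Compound 4 adds to the values held at a limit: the limit of > 100000 nM in this assay, at which 3 of the 4 values shown sit. The compounds shown leave open how strongly compound 2, compound 3 and compound 4 act, and whether the benzamido group changes anything.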